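The source may report more compounds than this note shows. Statements on the series, on what has been measured and on what is new or still open speak of the compounds shown alone.

Working notes on the series.

Compound 1 `Cn1ncc(Cl)c1-c1cc(C(=O)N[C@@H]2CN[C@H](CC(=O)NC3CC3)C[C@H]2c2ccc(Cl)c(Cl)c2)oc1Cl` is measured in an assay for inhibition of RAC-alpha serine/threonine-protein kinase (Homo sapiens), read by HTRF, with a stated time of 1 h (a higher number here means a weaker inhibitor, a lower number a stronger inhibitor), at 3.95 nM. Within the data shown here, the only other compound with a number, compound 2 `CC(=O)OCC[C@@H]1C[C@@H](c2ccc(F)c(F)c2)[C@H](NC(=O)c2cc(-c3c(Cl)cnn3C)c(Cl)o2)CN1`, gives in this assay a value of 3.4 nM; compound 1 holds the higher of the two numbers, but the gap to compound 2 sits within the scatter, so the two values read as the same.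

The next compound, compound 3 `Cn1ncc(Cl)c1-c1cc(C(=O)N[C@@H]2CN[C@H](CC(=O)NCCO)C[C@H]2c2ccc(Cl)c(Cl)c2)oc1Cl`, shares the core of compound 1 and is changed in one place: 2-hydroxyethyl in place of cyclopropyl on an amide-type nitrogen. The side where the change sits carries a carbamoylmethyl group on the shared core, and what is swapped is only what stands on the amide-type nitrogen of that group.

Among the measured compounds shown here, no measured pair in this set carries this change, so no step size can be read off for it. With both measured compounds sitting within the scatter of each other, the expectation for the step from compound 1 to compound 3 is a small one, a 1.3-fold higher number from compound 1 to compound 3 (0.10 log units; within the scatter), not clearly beyond the scatter in either direction. Compound 3 is therefore expected to give in this assay about 5 nM, with a range of 2 nM to 13 nM.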

Compound 3, half-maximal inhibitory concentration: 1.41 nM
Beside the measured number, compound 3's estimate is 3.5-fold (0.55 log units) above it; the measured number lies below the stated range.
By their numbers in this assay, from the lowest: compound 3; then compounds 2 and 1 (each within the scatter of the next).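

Among these compounds, on the amide-type nitrogen of the carbamoylmethyl group on the shared core, replacing cyclopropyl with 2-hydroxyethyl gives the first step that can be read in this assay: a 2.8-fold lower number from compound 1 to compound 3 (0.45 log units; beyond the scatter). This substituent is therefore not inert in this series, and a measurable change arises even though the heavy-atom count stays the same and the swap removes the ring and adds a hydrogen-bond donor and acceptor. No supporting data bear on the reason for this step, so the result remains an observation from a single pair.

The pair cannot separate the loss of the ring from the arrival of the hydroxyl, and a plain propyl group on the same nitrogen would be the direct comparison for that question, while 2-methoxyethyl would ask the same of the hydroxyl hydrogen. It also leaves open how far the trend extends to a longer chain such as 3-hydroxypropyl, to an amine such as 2-aminoethyl or to a carboxylic acid such as carboxymethyl, and whether the step holds on a core carrying a different aryl group.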